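Phenyl for vinyl on a thioether carbon in two inactive compounds

The source may report more compounds than this note shows. Statements on the series, on what has been measured and on what is new or still open speak of the compounds shown alone.

Compound 1, `Cc1nnc(SCc2ccccc2)n1N1C(=O)c2ccccc2C1=O`: in a functional assay on MKN-45 cells (Homo sapiens) for cytotoxicity, read by MTT assay, with a stated time of 48 h (a lower number here means a stronger inhibitor, a higher number a weaker inhibitor), compound 1 gives > 200000 nM.
Compound 2, `C=CCSc1nnc(CCC)n1N1C(=O)c2ccccc2C1=O`: in this assay compound 2 gives > 200000 nM.

Neither of these is a number. For compound 1 the value is a limit of the assay. Among the measured compounds shown here, for compound 2 the value is likewise only a limit, so compound 2 stands at the edge of what this assay can report, as does the one other value, (the limit of > 200000 nM in this assay, at which 2 of the 2 values shown sit).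

Compound 3, `CCCc1nnc(SCc2ccccc2)n1N1C(=O)c2ccccc2C1=O`, is not yet measured in this assay. It differs from compound 2 by phenyl in place of vinyl on a saturated chain carbon bound to a sulfur. With both measured compounds sitting at the limit, no step beyond the scatter is expected from this change, in either direction. Compound 3 is therefore expected to show a step that the limit leaves unreadable from compound 2 to compound 3 and an estimated value near 250000 nM, within a range from 100000 nM to 600000 nM.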

Compound 3, half-maximal inhibitory concentration: > 200000 nM
Compound 3 gave a limit, no number; the forecaster's own chance of this, stated with the estimate: 80%; the middle value is on the limit's open side.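

Compound 3 gives only a limit of the assay, as compound 1 and compound 2 do, so no step can be read from either of them to compound 3: the limit of > 200000 nM in this assay, at which 3 of the 3 values shown sit.

The compounds shown leave open whether phenyl in place of vinyl, or ethyl in place of hydrogen, changes the cytotoxicity at all.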